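This account rests on a few compounds, and the source may have more. Where it says the series, first, only, none or still open, it means among the compounds named here.

Measured in an assay on isolated protein for inhibition of activin receptor type-2A (Homo sapiens), read by 33P incorporation, with a stated time of 20 min, in the presence of a further agent that is not named here; a higher number here means a weaker inhibitor, a lower number a stronger inhibitor:
compound 1 `COc1cc(-c2cnn3cc(OC)c(-c4cnn(C)c4)nc23)ccn1`: 530 nM
compound 2 `COc1cc(-c2cnn3cc(OC)c(C(C)C)nc23)ccn1`: 3800 nM
compound 3 `CCc1nc2c(-c3ccnc(OC)c3)cnn2cc1OC`: 960 nM

Compound 3 holds the second highest of the three numbers in this assay; its nearest neighbour is compound 1, within the scatter, and its furthest is compound 2, beyond the scatter. Compound 4 `COc1cc(-c2cnn3cc(OC)c(C(C)(C)O)nc23)ccn1` differs from compound 3 in one place: 1-hydroxy-1-methylethyl in place of ethyl on an aromatic carbon. All variation in the measured set sits at this same position. The step with the closest bearing is a 4.0-fold lower number from compound 2 to compound 3 (0.60 log units; beyond the scatter), which runs opposite to the branching that compound 4 brings back, now with a hydroxyl on that carbon. The wider range at the position is set by a 7.2-fold higher number from compound 1 to compound 2 (0.86 log units; beyond the scatter) and a 1.8-fold higher number from compound 1 to compound 3 (0.26 log units; within the scatter). For the measured compounds named here, no measured compound carries a hydroxyl at this carbon, so that part of the change has no precedent here. A modest step back toward the number of compound 2 is expected, a 2.1-fold higher number from compound 3 to compound 4 (0.32 log units; beyond the scatter), with the hydroxyl treated as unknown. Compound 4 is estimated at 2000 nM, with a range from 700 nM to 6000 nM.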

Compound 4, half-maximal inhibitory concentration: 2700 nM
The estimate for compound 4 lay 1.4-fold (0.13 log units) below the measured number; the range from low to high includes it.
By their numbers in this assay, from the lowest: compounds 1 and 3 (each within the scatter of the next); then compounds 4 and 2 (each within the scatter of the next).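

Hydroxyl on the branched carbon gives no readable change in this assay: a 1.4-fold lower number from compound 2 to compound 4 (0.15 log units; within the scatter) leaves compound 4 and compound 2 within the scatter of each other, so the unknown part of this change now has a reading in this one pair. The 1-hydroxy-1-methylethyl group still gives up ground against ethyl, with a 2.8-fold higher number from compound 3 to compound 4 (0.45 log units; beyond the scatter), and against 1-methyl-1H-pyrazol-4-yl, with a 5.1-fold higher number from compound 1 to compound 4 (0.71 log units; beyond the scatter), so among these four compounds both branched groups sit on the high side, with no compound going against this. Nothing available on these compounds accounts for these steps.

Open, going by these compounds, is whether a hydroxyl on an unbranched chain, as in hydroxymethyl, would keep the number of compound 3 in this assay. Also open, on these data alone, is how an amine on the branched carbon, or a chain longer than ethyl such as propyl, would read at this position.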